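A few compounds are considered here, and "the series" means these few. Any claim that something is new, unique, unknown or untested is made for them only; others in the source may bear on it.

Measured compounds and their values:
- compound 1 `CCCCCCCCc1ccc(OCC(=O)Cn2nnc(-c3cccc(Cl)c3)n2)cc1`: 69%
- compound 2 `CCCCCCCCc1ccc(OCC(=O)Cn2nnc(C(=O)O)n2)cc1`: 52%
- compound 3 `CCCCCCCCc1ccc(OCC(=O)Cn2nnc(-c3cccc(C(=O)O)c3)n2)cc1`: < 5%

In an ADME assay on S9 fraction from liver (Rattus norvegicus) for metabolic stability, read by LC-MS, using NADPH, with a stated time of 30 min (on this read-out lower numbers stand for a less stable compound and higher numbers for a more stable compound), compound 1 gives 69% and compound 2 gives 52%. Compound 2 thus stands lowest of the two numbers, with compound 1 the nearest, and the change between them was a number 17 percentage points lower from compound 1 to compound 2 (beyond the scatter). For compound 3 this assay reports only a limit, < 5%, and the values sit as follows: the limit of < 5% in this assay, at which 1 of the 3 values shown sits. The steps to compound 3 were large: a number at least 64 percentage points lower from compound 1 to compound 3 (beyond the scatter) and a number at least 47 percentage points lower from compound 2 to compound 3 (beyond the scatter).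

The unmeasured compound 4 `CCCCCCCCc1ccc(OCC(=O)Cn2nnnc2C(=O)OC)cc1` differs from compound 2 by 5-(methoxycarbonyl)-1H-tetrazol-1-yl in place of 5-carboxy-2H-tetrazol-2-yl on a saturated chain carbon bound to a carbonyl carbon. Two of the measured steps touch the carboxy group, and both ran downward, but neither replaces the carboxy with a methoxycarbonyl, and none moves the point of attachment on the tetrazole. The measured steps therefore do not describe this change directly, and only a modest movement in this assay is expected, if any beyond the scatter, with a slight lean downward. Compound 4 is expected to give 45%, between 20% and 70%. This estimate amounts to an expected step of a number 7 percentage points lower from compound 2 to compound 4 (within the scatter), close to the scatter.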

Compound 4, percent of the compound remaining: 38%
Compound 4: middle estimate off by 7 percentage points, on the high side; measured number inside the range.
By their numbers in this assay, from the lowest: compound 4; then compound 2; then compound 1. At a limit, below all of these: compound 3.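

In this assay, putting 5-(methoxycarbonyl)-1H-tetrazol-1-yl in place of 5-carboxy-2H-tetrazol-2-yl on a saturated chain carbon bound to a carbonyl carbon gave a number 14 percentage points lower from compound 2 to compound 4 (beyond the scatter). The two earlier steps that brought in a carboxy group both lowered the number, yet this step, in which the free carboxy group and its hydrogen-bond donor leave, lowers it as well, so across these compounds the loss of a free carboxy group does not by itself raise the number. No measurement shown here accounts for the size or direction of this step.

From the compounds shown here alone, the step changes both the group on the tetrazole and its point of attachment, so the share of each remains open, and a 5-(methoxycarbonyl)-2H-tetrazol-2-yl group or a 5-carboxy-1H-tetrazol-1-yl group at this position would be needed to separate them. Going by these compounds, it also remains open whether a carboxamide or an ethyl ester in place of the methoxycarbonyl would give a number like that of compound 4, which stands at 38%.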